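The compounds below may be only part of what the source reports. "The series", "measured", "known", "first", "only" and "open" are said of these compounds alone.

In a functional assay on HEK293 cells for antagonist activity at transient receptor potential cation channel subfamily V member 1 (Homo sapiens), read by FLIPR (a lower number here means a stronger inhibitor, a higher number a weaker inhibitor), three compounds built on one shared core have been examined. Compound 1, `O=C(Nc1cccc2cnccc12)NC1CCc2cc(Cl)ccc2C1Cc1ccccc1`, gives 63 nM. Compound 2, `O=C(Nc1cccc2cnccc12)NC1CCc2cc(F)ccc2C1Cc1ccoc1`, gives 83 nM. For compound 3, `COc1ccc2c(c1)CCC(NC(=O)Nc1cccc3cnccc13)C2Cc1cccnc1`, the result is only a limit of the assay, > 1000 nM, and not a number. Among the two numbers that are known, compound 2 has the higher one, but its gap to compound 1 lies within the scatter, so the two cannot be placed in order.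

Compound 4, `O=C(Nc1cccc2cnccc12)NC1CCc2cc(F)ccc2C1Cc1ccc(C(F)(F)F)cc1`, is the next candidate. It departs from compound 2 in a single place: 4-(trifluoromethyl)phenyl in place of furan-3-yl on a saturated chain carbon bound to a saturated ring carbon. For the measured compounds named here, no measured pair differs in exactly this way, so there is no direct precedent for the step. With compound 1 standing at 63 nM and compound 2 at 83 nM, the expectation for compound 4 is a value in the same region, with the step of a 1.5-fold lower number from compound 2 to compound 4 (0.18 log units; within the scatter) expected to stay within or close to the scatter. The estimate for compound 4 is 55 nM, within a range from 15 nM to 200 nM.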

Compound 4, half-maximal inhibitory concentration: 10 nM
The estimate for compound 4 lay 5.5-fold (0.74 log units) above the measured number; measured number below the stated range.
By their numbers in this assay, from the lowest: compound 4; then compounds 1 and 2 (each within the scatter of the next). At a limit, above all of these: compound 3.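

In this assay, replacing furan-3-yl with 4-(trifluoromethyl)phenyl gives an 8.3-fold lower number from compound 2 to compound 4 (0.92 log units; beyond the scatter), with the rest of the molecule unchanged. For the compounds shown here, the earlier compounds differ from one another in more than one place, so this is the first direct sign that the group on this saturated chain carbon can shift the number beyond the scatter, and that a stronger inhibitor does not need the hydrogen-bond acceptor counted in furan-3-yl. Nothing measured here accounts for the size of this step.

This single pair cannot separate the change of ring from the arrival of the trifluoromethyl group, as the two come in together. Also open, from the compounds shown here alone, is what an amine or a carboxylic acid in place of that trifluoromethyl group would do to the number.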